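A few compounds are considered here, and "the series" means these few. Any claim that something is new, unique, unknown or untested is made for them only; others in the source may bear on it.

Of the compounds shown here, three built on one shared core have been tested in a toxicity assay on THP-1 cells (Homo sapiens) for inhibition; a higher number here means that more compound is tolerated, a lower number that less compound is tolerated. Compound 1 `COc1ccc(-c2cnc(NC(=O)c3ccc(F)cc3)n2C(C)C)cc1` gives > 50000 nM, which is a limit of the assay rather than a measured number. Compound 2 `COc1cccc(-c2cnc(NC(=O)c3ncc[nH]3)n2C)c1` gives > 100000 nM, again a limit of the assay. Compound 3 `COc1ccc(-c2cnc(NC(=O)c3cnco3)n2C)cc1` gives > 100000 nM, also a limit of the assay and not a number. So compound 3 stands at the limit of > 100000 nM in this assay, at which 2 of the 3 values shown sit, while the remaining value sits at the limit of > 50000 nM in this assay, at which 1 of the 3 values shown sits; no compound in this set has a measured number, and no step between measured compounds can be drawn.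

Compound 4 `COc1ccc(-c2cnc(NC(=O)c3cccc(O)c3)n2C)cc1` differs from compound 3 in one place: 3-hydroxyphenyl in place of 1,3-oxazol-5-yl on a carbonyl carbon. Nothing measured here points to a step in either direction, so the change from the 1,3-oxazol-5-yl to the 3-hydroxyphenyl on the carbonyl carbon is expected to bring none beyond the usual scatter; the expected step is a number no higher from compound 3 to compound 4 (the limit leaves the size open). Compound 4 is therefore estimated at 100000 nM in this assay, with a range from 30000 nM to 300000 nM, most likely reported once more only as a limit.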

Compound 4, half-maximal cytotoxic concentration: > 100000 nM
Compound 4: only a limit was reported; the forecaster's own chance of this, stated with the estimate: 75%; the middle value lies on the limit itself.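

For the compounds shown here, compound 3 and compound 4 are both reported only as limits of the assay, not as numbers, and no step between them can be read. The compounds shown leave open whether 3-hydroxyphenyl and 1,3-oxazol-5-yl on the carbonyl carbon differ in how much compound is tolerated.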